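The compounds below may be only part of what the source reports. "The series", "measured", "known", "first", "only" and "open" are said of these compounds alone.

Working notes on the series. Going by the values given here, the shared core carries a macrocycle with a urea unit, and the two members measured so far differ in the length of the chain linking that urea into the ring. Compound 1 `COc1ccc2c(O[C@@H]3C[C@H]4C(=O)N[C@]5(C(=O)NS(=O)(=O)C6CC6)C[C@H]5/C=C\CCCCCNC(=O)N4C3)cc(-c3nc(C(C)C)cs3)nc2c1` has the longer chain; in an in vivo ADME assay on the whole organism (strain Sprague-Dawley) for metabolic stability, with Rattus norvegicus as the target, at a dose of 10 mg/kg by the oral route (on this read-out higher numbers stand for a longer-lived compound and lower numbers for a shorter-lived compound), compound 1 gives 5.4 h. Compound 2 `COc1ccc2c(O[C@@H]3C[C@H]4C(=O)N[C@]5(C(=O)NS(=O)(=O)C6CC6)C[C@H]5/C=C\CCCCNC(=O)N4C3)cc(-c3nc(C(C)C)cs3)nc2c1` has a chain shorter by one link; in this assay compound 2 gives 3.8 h. The two values lie within the usual scatter of each other, so no ordering between compound 1 and compound 2 can be read from them.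

Compound 3 `COc1ccc2c(O[C@@H]3C[C@H]4C(=O)N[C@]5(C(=O)NS(=O)(=O)C6CC6)C[C@H]5/C=C\CCCCN(C)C(=O)N4C3)cc(-c3nc(C(C)C)cs3)nc2c1` is not yet measured in this assay. It differs from compound 2 by methyl in place of hydrogen on an amide-type nitrogen in a ring. Among the compounds with values here, no step between measured compounds informs this change, so nothing beyond the scatter is expected in either direction. The step of a 1.2-fold higher number from compound 2 to compound 3 (0.07 log units; within the scatter) is estimated to stay within the scatter. Compound 3 is expected to give about 4.5 h, with a range from 2.3 h to 9 h.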

Compound 3, half-life: 2.55 h
Estimate against measurement, compound 3: 1.8-fold (0.25 log units) above; the measured number falls inside the stated range.
By their numbers in this assay, from the lowest: compounds 3, 2 and 1 (each within the scatter of the next, the first and the last beyond it).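

In this assay methyl in place of hydrogen on the amide-type nitrogen in the ring gives a 1.5-fold lower number from compound 2 to compound 3 (0.17 log units; within the scatter) and so provides the first step read at this position. With this step inside the scatter, no ordering of compound 2 and compound 3 can be read, and the methyl on this nitrogen, a single added heavy atom, shows no effect on half-life that can be separated from the scatter. Nothing measured here bears on the reason for this result.

Going by these compounds, whether an ethyl group or a longer chain on this nitrogen would take the half-life beyond the scatter remains open. Also open, on these data alone, is whether the same methyl would give a comparable step on the longer chain of compound 1.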